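The source may hold more compounds than are shown below. What is called first, only, known or untested is meant among the compounds shown, and "the series" means these compounds.

Compound 1 `CC#C[C@H]1CN(S(=O)(=O)c2ccc(N)nc2)CCN1c1ncc(C(C)(O)C(F)(F)F)s1` and compound 2 `CC#C[C@H]1CN(S(=O)(=O)c2ccc(N)nc2)CCN1c1ccc(S(=O)(=NC)C(F)(F)F)cc1` share one core. In an assay on cells (Hepatocyte) for inhibition of glucokinase regulatory protein (Mus musculus), with stated times of 20 min and 40 min (on this read-out lower numbers stand for an effect already at smaller amounts and higher numbers for an effect only at larger amounts of compound), compound 1 returns only a limit of the assay, > 12500 nM. Going by the values given here, compound 2 gives 2060 nM in this assay, the sole real number among the two results; the other result sits at the limit of > 12500 nM in this assay, at which 1 of the 2 values shown sits. Compound 3 `CC#C[C@H]1CN(S(=O)(=O)c2ccc(N)nc2)CCN1c1ccc(S(=O)(=O)Nc2ccccc2)cc1` differs from compound 2 by a group of 10 heavy atoms (6 carbon, 1 nitrogen, 2 oxygen, 1 sulfur; one six-membered aromatic ring of carbon only) in place of a group of 8 heavy atoms (2 carbon, 1 nitrogen, 1 oxygen, 3 fluorine, 1 sulfur; no ring), on an aromatic carbon. Among the compounds with values here, no step between measured compounds is known to guide the size of this change, so a modest weakening is expected, a 1.7-fold higher number from compound 2 to compound 3 (0.23 log units; within the scatter). Compound 3 is estimated at 3500 nM in this assay, within a range from 800 nM to 15000 nM.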

Compound 3, half-maximal effective concentration: > 12500 nM
Compound 3: only a limit was reported (the forecaster's own chance of this, stated with the estimate: 25%); at least 3.5-fold (0.55 log units) between middle value and limit.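

In this assay, going by these compounds alone, placing phenylsulfamoyl on this aromatic carbon, para to a large group, gives an at least 6.0-fold higher number from compound 2 to compound 3 (0.78 log units; beyond the scatter), the only measured step at this position. The position therefore does not accept every group: this exchange carries a change beyond the scatter. Its true size stays unknown, since compound 3 returns only a limit of the assay, as compound 1 does: the limit of > 12500 nM in this assay, at which 2 of the 3 values shown sit.

As far as these compounds go, the exchange brings in the phenyl ring and the nitrogen-bound hydrogen together, so their separate shares stay open. A plain sulfamoyl or a methylsulfonyl group here would help to separate them.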